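Working notes: inverting one stereocentre

The source may hold more compounds than are shown below. What is called first, only, known or untested is meant among the compounds shown, and "the series" means these compounds.

- compound 1 `N[C@]1(CO)CC[C@H](c2ccc3c(c2)CC[C@H](CCc2ccccc2)C3)C1`: > 75 h (a limit)
- compound 2 `COc1cccc(CC[C@@H]2CCc3cc([C@H]4CC[C@](N)(CO)C4)ccc3C2)c1`: 31 h

Among the measured compounds shown here, in an ADME assay on the whole organism (Rattus norvegicus, strain Lewis) for metabolic stability, read by LC-MS, with a stated time of 72 h, at a dose of 2 mg/kg by the oral route (on this read-out higher numbers stand for a longer-lived compound and lower numbers for a shorter-lived compound), compound 2 gives 31 h, the only exact number so far. The entry for compound 1 is a limit and not a number.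

Compound 3 `COc1cccc(CC[C@H]2CCc3cc([C@H]4CC[C@](N)(CO)C4)ccc3C2)c1` has the same atoms and bonds as compound 2 and differs only in configuration as drawn: the two compounds have the same atoms and bonds and differ only in configuration as drawn: 1 of 3 stereo elements differ; a stereocentre at a saturated ring carbon is drawn R in compound 2 and S in compound 3.

For the measured compounds named here, no measured pair shows the effect of such a change, so no step beyond the scatter is expected in this assay. The expected step is a 1.0-fold lower number from compound 2 to compound 3 (0.01 log units; within the scatter). For compound 3 the estimate is 30 h, with an expected range of 15 h to 60 h.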

Compound 3, half-life: 49 h
The estimate for compound 3 lay 1.6-fold (0.21 log units) below the measured number; low and high end bracket the measured number.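

In this assay, the stereocentre at the saturated ring carbon now has its first measured pair, with a 1.6-fold higher number from compound 2 to compound 3 (0.20 log units; within the scatter). This pair isolates configuration as the only change: the fact that compounds 2 and 3 differ only in the configuration as drawn

Methoxy in place of hydrogen on an aromatic carbon goes with an at least 1.5-fold lower number from compound 1 to compound 3 (0.18 log units; that floor lies within the scatter), and this step is only a floor because one side of it rests on a limit: the limit of > 75 h in this assay, at which 1 of the 3 values shown sits.

From the compounds shown here alone, the full size of the methoxy step stays open. So does whether an ethoxy or a chlorine in place of methoxy, or inversion of the same stereocentre without methoxy, would give a different read-out.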